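The source may hold more compounds than are shown below. What is called first, only, known or untested is meant among the compounds shown, and "the series" means these compounds.

Three compounds have been measured in a functional assay on B16-F10 cells (Mus musculus) for inhibition, read by MTT assay, with a stated time of 72 h; on this read-out higher numbers stand for weaker inhibition and lower numbers for stronger inhibition:

Compound 1, `Cc1ccc(Nc2nc(SCc3cn(CC(=O)NC(=O)Nc4ccccn4)nn3)nc(-c3ccc(C(C)C)cc3)c2C#N)cc1`, gives 3060 nM.
Compound 2, `CC(C)c1ccc(Nc2nc(SCc3cn(CC(=O)NC(=O)Nc4ccccn4)nn3)nc(-c3ccc(C(C)C)cc3)c2C#N)cc1`, gives 4380 nM.
Compound 3, `COc1cc(-c2nc(SCc3cn(CC(=O)NC(=O)Nc4ccccn4)nn3)nc(Nc3ccc(C(C)C)cc3)c2C#N)cc(OC)c1OC`, gives 1210 nM.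

Compound 3 shows the lowest number of the three in this assay, and its gap to both compound 1 and compound 2 lies beyond the usual scatter. The new compound 4, `COc1cc(-c2nc(SCc3cn(CC(=O)NC(=O)Nc4ccccn4)nn3)nc(Nc3ccc(C)cc3)c2C#N)cc(OC)c1OC`, keeps the core of compound 3 and differs in one place: methyl in place of isopropyl on an aromatic carbon.

Among the compounds with values here, only one measured step bears directly on this change, and it runs in the opposite direction: a 1.4-fold higher number from compound 1 to compound 2 (0.16 log units; within the scatter). Reversing it, methyl in place of isopropyl on the same aromatic carbon, would on that evidence be expected to lower the number a little, but not beyond the scatter. The other step, a 3.6-fold lower number from compound 2 to compound 3 (0.56 log units; beyond the scatter), concerns a different part of the molecule and so says nothing about this exchange.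

For compound 4 the number in this assay is therefore expected to sit close to that of compound 3, with the step of a 1.2-fold lower number from compound 3 to compound 4 (0.08 log units; within the scatter) estimated as small. The estimate for compound 4 is 1000 nM, with a range from 500 nM to 2200 nM.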

Compound 4, half-maximal inhibitory concentration: 32 nM
Compound 4: the middle estimate sits 31-fold (1.49 log units) above what was measured, and the stated range ends above it.
By their numbers in this assay, from the lowest: compound 4; then compound 3; then compounds 1 and 2 (each within the scatter of the next).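

In this assay, replacing the (4-isopropylphenyl)amino group with the (4-methylphenyl)amino group produces a 38-fold lower number from compound 3 to compound 4 (1.58 log units; beyond the scatter), so removing two carbons here can matter far more than the earlier pair suggested. The size of this exchange depends on the group elsewhere in the molecule, since it differs sharply between the core with the 4-isopropylphenyl group and the core with the 3,4,5-trimethoxyphenyl group: the same change on two cores in this assay, a 1.4-fold higher number (0.16 log units; within the scatter) from compound 1 to compound 2 and a 38-fold higher number (1.58 log units; beyond the scatter) from compound 4 to compound 3, 26-fold (1.42 log units) apart, beyond the scatter of two such steps. The reverse view tells the same story, with the 3,4,5-trimethoxyphenyl group giving a 96-fold lower number from compound 1 to compound 4 (1.98 log units; beyond the scatter) when the 4-methylphenyl group is present, so the two changes do not act independently: the same change on two cores in this assay, a 3.6-fold lower number (0.56 log units; beyond the scatter) from compound 2 to compound 3 and a 96-fold lower number (1.98 log units; beyond the scatter) from compound 1 to compound 4, 26-fold (1.42 log units) apart, beyond the scatter of two such steps.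

From the compounds shown here alone, it remains open whether methyl is uniquely favourable in this place or only one point on a trend, which groups such as hydrogen, ethyl, methoxy or chlorine on the same core could help settle. With only four compounds, and the very low number resting on compound 4 alone, it is also unclear how far this dependence extends to other groups on the shared core.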